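From Compound 2 to Compound 4 on the Amide Nitrogen

This account rests on a few compounds, and the source may have more. Where it says the series, first, only, none or still open, it means among the compounds named here.

Of the compounds shown here, three sharing one core have been measured in a functional assay (QGY7701 cells, Homo sapiens) for inhibition, read by MTT assay, with a stated time of 48 h; on this read-out lower numbers stand for stronger inhibition and higher numbers for weaker inhibition. Compound 1 `O=C(/C=C/c1coc2cc(O)ccc2c1=O)NCc1ccccc1` gives 63000 nM, compound 2 `COc1cccc(NC(=O)/C=C/c2coc3cc(OC)ccc3c2=O)c1` gives 39100 nM, and compound 3 `Cc1ccc(CNC(=O)/C=C/c2coc3cc(O)ccc3c2=O)cc1` gives 24900 nM. Compound 2 is the second highest of these three numbers, yet lies within the scatter of both others. Compound 4 `COc1ccc2c(=O)c(/C=C/C(=O)Nc3ccc(C)cc3)coc2c1` differs from compound 2 in one place: 4-methylphenyl in place of 3-methoxyphenyl on an amide-type nitrogen. Within the data shown here, the only measured step, a 2.5-fold lower number from compound 1 to compound 3 (0.40 log units; beyond the scatter), concerns a methyl in place of hydrogen on an aromatic carbon rather than a change on the amide nitrogen, so it bears only loosely on this swap. Compound 4 is therefore expected to show a step of a 1.3-fold lower number from compound 2 to compound 4 (0.12 log units; within the scatter), not beyond the scatter. The estimate for compound 4 is 30000 nM, ranging from 12000 nM to 75000 nM.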

Compound 4, half-maximal inhibitory concentration: 39300 nM
Beside the measured number, compound 4's estimate is 1.3-fold (0.12 log units) below it; low and high end bracket the measured number.
By their numbers in this assay, from the lowest: compounds 3, 2, 4 and 1 (each within the scatter of the next, the first and the last beyond it).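

Placing 4-methylphenyl in place of 3-methoxyphenyl on the amide-type nitrogen gives a 1.0-fold higher number from compound 2 to compound 4 (0.00 log units; within the scatter) in this assay and is the first step shown at this place. The group that enters has 0 hydrogen-bond acceptors and the group that leaves has 1, yet the read-out stays within the scatter. Nothing measured here explains this result.

Still open, as far as these compounds go, is whether this place tolerates every change or only these two substituted phenyl groups. An amine, a carboxylic acid or a longer chain on the amide nitrogen would test that.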